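The source may report more compounds than this note shows. Statements on the series, on what has been measured and on what is new or still open speak of the compounds shown alone.

Compound 1 `CCN(Cc1c(C(F)(F)F)nc2n(-c3c(C)cc(C)cc3C)c(Cl)cn12)CC1CC1`: 9 nM
Compound 2 `Cc1cc(C)c(-n2c(Cl)cn3c(CN(CCC(F)(F)F)CC4CC4)c(C(F)(F)F)nc23)c(C)c1`: 16 nM
Compound 3 `CCCN(Cc1c(C(F)(F)F)nc2n(-c3c(C)cc(C)cc3C)c(Cl)cn12)CC1CCC1`: 5.3 nM

In an assay on cells for displacement of a labelled ligand from corticotropin-releasing factor receptor 1 (Homo sapiens), with a stated time of 100 min (a lower number here means a stronger inhibitor, a higher number a weaker inhibitor), compound 3 gives the lowest of the three numbers, 5.3 nM. Its nearest neighbour is compound 1, reached by a 1.7-fold lower number from compound 1 to compound 3 (0.23 log units; within the scatter), a step that stays within the scatter, so the two cannot be ranked against each other. Compound 2 stands furthest away: a 3.0-fold lower number from compound 2 to compound 3 (0.48 log units; beyond the scatter) is a modest step beyond the scatter. Between compound 1 and compound 2 the difference is a 1.8-fold higher number from compound 1 to compound 2 (0.25 log units; within the scatter), within the scatter.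

Compound 4 `Cc1cc(C)c(-n2c(Cl)cn3c(CN(C)Cc4ccco4)c(C(F)(F)F)nc23)c(C)c1` arises from compound 3 through (((furan-2-yl)methyl)(methyl)amino in place of (cyclobutylmethyl)(propyl)amino on a saturated chain carbon bound to an aromatic carbon). Going by the values given here, none of the measured steps is this change. The two steps that touch the same place, a 1.7-fold lower number from compound 1 to compound 3 (0.23 log units; within the scatter) and a 3.0-fold lower number from compound 2 to compound 3 (0.48 log units; beyond the scatter), show that rebuilding the amino group there has moved the number by only a small or modest amount, in either direction. Among the compounds with values here, the expected step of a 2.8-fold higher number from compound 3 to compound 4 (0.45 log units; beyond the scatter) is therefore estimated to be at most modest, and more likely toward a higher number than a lower one, since every variation at this place so far has left compound 3 with the lowest value. For compound 4 the expected value in this assay is 15 nM, within a range from 5 nM to 50 nM.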

Compound 4, inhibition constant: 180 nM
Beside the measured number, compound 4's estimate is 12-fold (1.08 log units) below it; the whole stated range lies below it.
By their numbers in this assay, from the lowest: compounds 3, 1 and 2 (each within the scatter of the next, the first and the last beyond it); then compound 4.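

In this assay, the amino group on the saturated chain carbon bound to an aromatic carbon proved far more sensitive than compounds 1, 2 and 3 had indicated: a 34-fold higher number from compound 3 to compound 4 (1.53 log units; beyond the scatter) and a 20-fold higher number from compound 1 to compound 4 (1.30 log units; beyond the scatter) and an 11-fold higher number from compound 2 to compound 4 (1.05 log units; beyond the scatter) are all large steps, whereas the steps among the earlier three were small or modest. Going by these compounds alone, those three all carry a cycloalkylmethyl group and a saturated chain of two or three carbons on the amine nitrogen, so they explored only a narrow part of this position; compound 4, with ((furan-2-yl)methyl)(methyl)amino, is the only one with an aromatic ring on that nitrogen and the only one with a methyl there, and it stands clearly apart from all of them. Nothing available explains the size of this loss.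

The compounds shown leave open whether the loss follows the furan-2-yl ring or the methyl group, since both entered together. A (cyclobutylmethyl)(methyl)amino group and a ((furan-2-yl)methyl)(propyl)amino group on the same core would separate the two parts of the change.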